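Larger Amino-Aryl Group and Expected Oral Exposure in Rats

A few compounds are considered here, and "the series" means these few. Any claim that something is new, unique, unknown or untested is made for them only; others in the source may bear on it.

Two compounds have numbers in an ADME assay on the whole organism (plasma) for pharmacokinetics, with Rattus norvegicus as the target, with a stated time of 6 h, at a dose of 10 mg/kg by the oral route; a higher number here means more compound in the circulation at the dose given, a lower number less compound in the circulation. Compound 1 `Nc1ccc(CS(=O)(=O)N2CCN(c3cnn(-c4cc(F)cc(F)c4)c(=O)c3OC3CCCC3)CC2)cc1` gives 8100 ng.h/mL, and compound 2 `CC1(COc2c(N3CCN(S(=O)(=O)Cc4cccc(N)c4)CC3)cnn(-c3cccc(Cl)c3)c2=O)CC1` gives 5700 ng.h/mL; compound 2 stands lowest of the two, yet its gap from compound 1 lies within the scatter. Compound 3 `CC(C)c1cc(CS(=O)(=O)N2CCN(c3cnn(-c4cccc(Cl)c4)c(=O)c3OCC3(C)CC3)CC2)ccc1N` differs from compound 2 in one place: 4-amino-3-isopropylphenyl in place of 3-aminophenyl on a saturated chain carbon bound to a sulfonyl sulfur. Among the compounds with values here, no measured pair shows how such a change moves exposure, so the direction is uncertain. For compound 3 a small downward step, not beyond the scatter, is expected: a 1.4-fold lower number from compound 2 to compound 3 (0.15 log units; within the scatter). Compound 3 is therefore estimated at 4000 ng.h/mL, within a range from 1500 ng.h/mL to 10000 ng.h/mL.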

Compound 3, area under the concentration-time curve: 2100 ng.h/mL
For compound 3 the middle estimate is 1.9-fold (0.28 log units) above the measured one; the range from low to high includes it.
By their numbers in this assay, from the lowest: compound 3; then compounds 2 and 1 (each within the scatter of the next).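

Within the data shown here, putting 4-amino-3-isopropylphenyl in place of 3-aminophenyl on a saturated chain carbon bound to a sulfonyl sulfur gives the first readable step at this position: in this assay there is a 2.7-fold lower number from compound 2 to compound 3 (0.43 log units; beyond the scatter). Exposure at this position therefore depends on which aryl group it carries, and here the larger group goes with less compound in the circulation. Nothing measured here bears on why the number falls.

The change shifts the amino group and adds isopropyl at once, so the compounds shown cannot separate those two parts. Also open, going by these compounds, is whether 4-amino-3-methylphenyl, with methyl in place of isopropyl, would give a smaller step.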